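Swapping a pyridine for a methylpyrazole on a urea scaffold

The source may hold more compounds than are shown below. What is called first, only, known or untested is meant among the compounds shown, and "the series" means these compounds.

Measured compounds and their values:
Compound 1, `Cc1cc(C)c(NC(=O)N(Cc2ccc(-c3ccccc3)s2)C2CCCCCC2)c(C)c1`: 46 nM
Compound 2, `O=C(Nc1c(F)cc(F)cc1F)N(Cc1ccc(-c2ccccn2)cc1)C1CCCCCC1`: 25 nM
Compound 3, `Cc1cc(C)c(NC(=O)N(Cc2ccc(-c3ccccn3)cc2)C2CCCCCC2)c(C)c1`: 33 nM

All three compounds were tested in an assay on microsomes from intestine for inhibition of acyl-CoA:cholesterol acyltransferase (Oryctolagus cuniculus); on this read-out lower numbers stand for stronger inhibition and higher numbers for weaker inhibition. Compound 3 gives 33 nM, the second highest of the three numbers; compound 2 gives 25 nM and compound 1 gives 46 nM, and both of these lie within the scatter of compound 3.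

The next compound, compound 4, `Cc1cc(C)c(NC(=O)N(Cc2ccc(-c3ccn(C)n3)cc2)C2CCCCCC2)c(C)c1`, carries a 1-methyl-1H-pyrazol-3-yl in place of the pyridin-2-yl of compound 3: 1-methyl-1H-pyrazol-3-yl in place of pyridin-2-yl on an aromatic carbon. The change sits on an aromatic carbon of a six-membered aromatic ring of carbon only.

Among the measured compounds shown here, only one measured step exists, a 1.3-fold higher number from compound 2 to compound 3 (0.12 log units; within the scatter), and it concerns the aryl group on the urea nitrogen, not the ring that is exchanged here; it therefore says little about this step. Compounds 1 and 3 differ in more than one place, so their values alone cannot be read as a single effect. For the measured compounds named here, with no direct precedent, a small shift is expected, possibly toward a weaker number.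

Compound 4 is estimated at 50 nM, with a likely range of 15 nM to 160 nM, a step of a 1.5-fold higher number from compound 3 to compound 4 (0.18 log units; within the scatter) expected from compound 3.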

Compound 4, half-maximal inhibitory concentration: 44 nM
Compound 4: middle estimate off by 1.1-fold (0.06 log units), on the high side, within the range that was stated.
By their numbers in this assay, from the lowest: compounds 2, 3, 4 and 1 (each within the scatter of the next).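

In this assay, putting 1-methyl-1H-pyrazol-3-yl in place of pyridin-2-yl gives a 1.3-fold higher number from compound 3 to compound 4 (0.12 log units; within the scatter) and so leaves the read-out unable to tell the two groups apart. Among the compounds shown here, this is the first measured change at this aromatic carbon, and it shows that a five-membered aromatic ring with two hetero atoms and a six-membered aromatic ring with one hetero atom can stand here with no difference beyond the scatter. No measurement on hand explains this result.

Going by these compounds, whether the same holds for a very different group at this carbon, such as a carboxylic acid or a morpholine, remains open. Also open, on these data alone, is whether this exchange would give a similar result with 2,4,6-trifluorophenyl in place of 2,4,6-trimethylphenyl on the urea.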